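Inverting both stereocentres of compound 1

The compounds below may be only part of what the source reports. "The series", "measured", "known", "first", "only" and "open" are said of these compounds alone.

- compound 1 `CCOC(=O)[C@@]1(C(=O)NCc2ccc(C)cc2)C[C@H]1c1cc(OC)c(OC)c(OC)c1`: > 100000 nM, a limit
- compound 2 `COc1cc([C@@H]2C[C@@]2(CO)C(=O)NCc2ccc(C)cc2)cc(OC)c1OC`: 76300 nM
- compound 3 `CCOC(=O)[C@@]1(C(=O)Nc2ccccc2)C[C@H]1c1cc(OC)c(OC)c(OC)c1`: > 100000 nM, a limit

All values come from a functional assay on SW480 cells (Homo sapiens) for cytotoxicity, read by MTT assay, with a stated time of 48 h; on this read-out lower numbers stand for stronger inhibition and higher numbers for weaker inhibition. Compound 1 is known only as a limit, and it sits at the limit of > 100000 nM in this assay, at which 2 of the 3 values shown sit.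

Compound 4 `CCOC(=O)[C@]1(C(=O)NCc2ccc(C)cc2)C[C@@H]1c1cc(OC)c(OC)c(OC)c1` is related to it as follows: the two compounds have the same atoms and bonds and differ only in configuration as drawn: 2 of 2 stereo elements differ (all stereocentres are inverted: mirror images); a stereocentre at a saturated ring carbon is drawn S in compound 1 and R in compound 4; a stereocentre at a saturated ring carbon is drawn S in compound 1 and R in compound 4.

Two measured steps start from compound 1: an at least 1.3-fold lower number from compound 1 to compound 2 (0.11 log units; that floor lies within the scatter), and a step that the two limits leave unreadable from compound 1 to compound 3. Neither alters configuration, so neither gives a size for this change, and no direction is expected. The expectation rests on compound 1, whose value > 100000 nM is a limit. The expected step is a number no higher from compound 1 to compound 4 (the limit leaves the size open). Compound 4 is estimated at 100000 nM, with an expected range of 35000 nM to 200000 nM.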

Compound 4, half-maximal inhibitory concentration: > 100000 nM
Compound 4: a limit, no number; the forecaster's own chance of this, stated with the estimate: 70%; the middle value sits exactly at the limit.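

Compound 1 and compound 4 are both known only as limits, and no step can be read between them. The compounds shown leave open whether inverting both stereocentres changes the read-out at all.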